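Swapping an aromatic ring for a ring-opened cousin

This account rests on a few compounds, and the source may have more. Where it says the series, first, only, none or still open, it means among the compounds named here.

The shared core carries a small ring on one aromatic carbon, and the study asks how the choice of that ring shows up in a functional assay on the whole organism (strain albino) for inhibition, with Rattus norvegicus as the target, read by paw edema, in the formalin test, with a stated time of 1 h, at a dose of 10 mg/kg by the oral route; on this read-out higher numbers stand for more inhibition at the one dose given (going by the name of the read-out) and lower numbers for less inhibition. Compound 1 `Cc1c(C(N)=O)sc2nc(NN)n(Cc3ccccc3)c(=O)c12` bears an aminoamino group there and gives 43% in this assay. Within the data shown here, compound 2 `Cc1cc(C)n(-c2nc3sc(C(N)=O)c(C)c3c(=O)n2Cc2ccccc2)n1` bears a 3,5-dimethyl-1H-pyrazol-1-yl group and gives 39% in this assay, the lowest of the two numbers so far, although the step of a number 4 percentage points lower from compound 1 to compound 2 (within the scatter) lies within the scatter, so the two compounds cannot be told apart.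

Compound 3 `CC1=NN(c2nc3sc(C(N)=O)c(C)c3c(=O)n2Cc2ccccc2)C(=O)C1` has not yet been measured. Its change from compound 2 is a group of 7 heavy atoms (4 carbon, 2 nitrogen, 1 oxygen; one five-membered non-aromatic ring with 2 hetero atoms) in place of a group of 7 heavy atoms (5 carbon, 2 nitrogen; one five-membered aromatic ring with 2 hetero atoms), on an aromatic carbon. Among the measured compounds shown here, the only measured step, a number 4 percentage points lower from compound 1 to compound 2 (within the scatter), concerns the same position but a different pair of groups, and it was too small to show a direction. For the measured compounds named here, no measured step speaks to an aromatic ring giving way to a non-aromatic one, so the expectation is a step of no size beyond the scatter. For compound 3 the estimated step is no change at the digits printed from compound 2 to compound 3 (within the scatter). Compound 3 is therefore expected to give about 39% in this assay, within a range from 27% to 51%.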

Compound 3, a percentage reported as inhibition, in the whole organism at one dose (the size of the read-out at that dose, not a potency): 39%
Compound 3: middle estimate and measured number agree at the digits printed; low and high end bracket the measured number.
By their numbers in this assay, from the lowest: compounds 2, 3 and 1 (each within the scatter of the next).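

In this assay, compound 3 shows that the aromatic ring at this position is not needed to keep the read-out in the same range: the 3,5-dimethyl-1H-pyrazol-1-yl group gives way to a five-membered non-aromatic ring with no change at the digits printed from compound 2 to compound 3 (within the scatter). Set against the open-chain aminoamino group, which has no ring at all, the same new ring gives a number 4 percentage points lower from compound 1 to compound 3 (within the scatter), so the three groups on this aromatic carbon cannot be told apart at the one dose given. Nothing measured on these compounds offers a reason for this sameness.

The compounds shown leave open whether any group at this place can move the number beyond the usual scatter, and a morpholine, a carboxylic acid or a longer chain on the same aromatic carbon would test that. Also open, on these data alone, is whether the three compounds would still match at other doses, as a reading at a single dose gives the size of the effect there and not a potency.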